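The compounds below may be only part of what the source reports. "The series", "measured", "known", "first", "only" and "open" are said of these compounds alone.

Of the compounds shown here, three built on one shared core have been measured in an in vitro functional assay on HEK285-7 cells for antagonist activity at prostaglandin D2 receptor 2 (Homo sapiens), read by BRET and beta-arrestin recruitment; a lower number here means a stronger inhibitor, a higher number a weaker inhibitor. Compound 1 `O=C(O)Cc1sc(C(c2ccc(F)cc2)c2ccc(F)cc2)nc1-c1cn[nH]c1` gives 220 nM; compound 2 `O=C(O)Cc1sc(C(c2ccc(F)cc2)c2ccc(F)cc2)nc1-c1ccncc1` gives 40 nM; compound 3 `O=C(O)Cc1sc(C(c2ccc(F)cc2)c2ccc(F)cc2)nc1-c1ccnc(Cl)c1` gives 39 nM. Compound 3 carries the lowest number of the three, but its gap to compound 2 lies within the scatter, while compound 1 stands clearly higher. Compound 4 `O=C(O)Cc1sc(C(c2ccc(F)cc2)c2ccc(F)cc2)nc1-c1ccnc(O)c1` differs from compound 3 by hydroxy in place of chloro on an aromatic carbon. The step that bears most directly on this is a 1.0-fold lower number from compound 2 to compound 3 (0.01 log units; within the scatter), showing that a chloro at this position changed little; a 5.5-fold lower number from compound 1 to compound 2 (0.74 log units; beyond the scatter) and a 5.6-fold lower number from compound 1 to compound 3 (0.75 log units; beyond the scatter) concern exchange of the whole ring and say less here. A hydroxy at the same spot is therefore expected to give a step of about a 1.4-fold higher number from compound 3 to compound 4 (0.15 log units; within the scatter), not beyond the scatter. Compound 4 is thus estimated at 55 nM, within 20 nM to 160 nM.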

Compound 4, half-maximal inhibitory concentration: 890 nM
Beside the measured number, compound 4's estimate is 16-fold (1.21 log units) below it; the whole stated range lies below it.
By their numbers in this assay, from the lowest: compounds 3 and 2 (each within the scatter of the next); then compound 1; then compound 4.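

In this assay, the place next to the ring nitrogen had accepted chloro with no real change, but it is not indifferent to every group: hydroxy in place of chloro gives a 23-fold higher number from compound 3 to compound 4 (1.36 log units; beyond the scatter) and hydroxy in place of hydrogen gives a 22-fold higher number from compound 2 to compound 4 (1.35 log units; beyond the scatter) on the same ring. The 2-hydroxypyridin-4-yl group even ends up behind the 1H-pyrazol-4-yl group, with a 4.0-fold higher number from compound 1 to compound 4 (0.61 log units; beyond the scatter) as the step. Nothing at hand explains this loss.

The compounds shown leave open how a methoxy group or an amine would fare at this place, and so whether hydroxy stands alone in giving such a rise.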